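Furan-2-yl in place of benzofuran-2-yl on the nucleoside core

The source may report more compounds than this note shows. Statements on the series, on what has been measured and on what is new or still open speak of the compounds shown alone.

Compound 1 `CNc1ncnc2c1c(I)cn2[C@@H]1O[C@H](CO)[C@@H](O)[C@H]1O` gives > 100000 nM in a functional assay on K562 cells (Homo sapiens), read by MTT assay, with a stated time of 72 h (a higher number here means a weaker inhibitor, a lower number a stronger inhibitor), a limit of the assay.
Compound 2 `CNc1ncnc2c1c(-c1ccccc1)cn2[C@@H]1O[C@H](CO)[C@@H](O)[C@H]1O` gives > 20000 nM in this assay, a limit.
Compound 3 `CNc1ncnc2c1c(-c1cc3ccccc3o1)cn2[C@@H]1O[C@H](CO)[C@@H](O)[C@H]1O` gives > 20000 nM in this assay, a limit.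

Compound 3 stands at the limit of > 20000 nM in this assay, at which 2 of the 3 values shown sit, so no number is known for it. The three measured steps, a step that the two limits leave unreadable from compound 1 to compound 2, a step that the two limits leave unreadable from compound 1 to compound 3 and a step that the two limits leave unreadable from compound 2 to compound 3, are all unreadable, so no step size is known for any change at this position. Compound 4 `CNc1ncnc2c1c(-c1ccco1)cn2[C@@H]1O[C@H](CO)[C@@H](O)[C@H]1O` differs from compound 3 as follows: furan-2-yl in place of 1-benzofuran-2-yl on an aromatic carbon. Among the measured compounds shown here, none of the measured steps gives a readable size, so no direction can be expected beyond the scatter for a step that the limit leaves unreadable from compound 3 to compound 4 in this assay. Compound 4 is expected to give 50000 nM, within 15000 nM to 200000 nM, most likely again as a limit.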

Compound 4, half-maximal inhibitory concentration: 220 nM
Compound 4: middle estimate off by 230-fold (2.36 log units), on the high side; the whole stated range lies above it.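

At this position activity in this assay depends on the group: furan-2-yl gives an at least 90-fold lower number from compound 3 to compound 4 (1.95 log units; beyond the scatter), an at least 90-fold lower number from compound 2 to compound 4 (1.95 log units; beyond the scatter) and an at least 450-fold lower number from compound 1 to compound 4 (2.65 log units; beyond the scatter). Among the compounds shown here, the steps among compounds 1, 2 and 3 cannot be read, so these are the first sizes known for any change here. The added six-membered aromatic ring of 1-benzofuran-2-yl separates compound 3 from compound 4, as the two groups otherwise share the five-membered aromatic ring with 1 hetero atom.

The compounds shown leave open whether thiophen-2-yl, with sulfur in place of the ring oxygen, or furan-3-yl would keep this activity.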